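Replacing an amide side chain with a fluorinated aryl ring

The source may hold more compounds than are shown below. What is called first, only, known or untested is meant among the compounds shown, and "the series" means these compounds.

Measured compounds:
- compound 1, `O=C1Nc2ccc(C(=O)c3ccco3)cc2/C1=C/c1cc(F)c(O)c(F)c1`: 21%
- compound 2, `O=C1Nc2ccc(C(=O)NCc3ccccc3)cc2/C1=C/c1cc(Cl)c(O)c(Cl)c1`: -24%

Of the compounds shown here, two have been tested in an assay on HeLa cells for inhibition of Kinesin-like protein KIF15 (Homo sapiens), read by microscopy, with stated times of 2 s and 20 s, tested at 750 nM; a lower number here means less inhibition, a higher number more inhibition at the concentration tested (going by the name of the read-out). Compound 1, `O=C1Nc2ccc(C(=O)c3ccco3)cc2/C1=C/c1cc(F)c(O)c(F)c1`, gives 21% in this assay. Compound 2, `O=C1Nc2ccc(C(=O)NCc3ccccc3)cc2/C1=C/c1cc(Cl)c(O)c(Cl)c1`, gives -24% in this assay. Compound 2 thus stands at the lowest of the two numbers, with compound 1 a step above it that is beyond the usual scatter. The two compounds differ in more than one place, so this gap cannot be assigned to any single change.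

Compound 3, `O=C1Nc2ccc(-c3cccc(F)c3)cc2/C1=C/c1cc(Cl)c(O)c(Cl)c1`, has not yet been measured. It differs from compound 2 by the following change: 3-fluorophenyl in place of benzylcarbamoyl on an aromatic carbon. Going by the values given here, no step between measured compounds isolates this change, so the expectation rests on the values of compound 1 and compound 2 alone. An increase in this assay is expected, of a size close to the edge of the scatter, giving an expected step of a number 34 percentage points higher from compound 2 to compound 3 (beyond the scatter). For compound 3 the estimated value in this assay is 10%, with a range from -25% to 45%.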

Compound 3, a percentage reported as inhibition, at one concentration (the size of the read-out at that concentration, not a potency): -5.8%
Beside the measured number, compound 3's estimate is 15.8 percentage points above it, and the stated range covers the measured number.
By their numbers in this assay, from the lowest: compound 2; then compound 3; then compound 1.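

At the aromatic carbon that is para to a fused ring, in this assay, 3-fluorophenyl in place of benzylcarbamoyl gives a number 18.2 percentage points higher from compound 2 to compound 3 (beyond the scatter), the first step shown that isolates a single change at this position. The read-out therefore responds to what sits at this position, and the rise comes with a swap from a group with 1 hydrogen-bond donor and 1 hydrogen-bond acceptor to one with neither, although compound 3 still gives a negative number at -5.8%. Nothing shown accounts for this step.

The change removes the amide and the benzyl chain and adds a fluorine in a single move, so the compounds shown cannot tell which of these parts carries the step. From the compounds shown here alone, it also remains open how the read-out would respond at this position to an unsubstituted phenyl, to a fluorine at another place on the ring, or to a phenyl ring bearing a carboxylic acid or an amine.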